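The source may report more compounds than this note shows. Statements on the series, on what has been measured and on what is new or still open speak of the compounds shown alone.

Compound 1 `COc1cc2nc(N3CCC(N4CCCC4)CC3)nc(Nc3ccc(F)c(F)c3)c2cc1OC` gives 69 nM in a functional assay for antagonist activity at C-C chemokine receptor type 4 (Homo sapiens), read by luminescence; on this read-out higher numbers stand for weaker inhibition and lower numbers for stronger inhibition.
Compound 2 `COc1cc2nc(N3CCC(N4CCCC4)CC3)nc(Nc3ccc(Cl)cc3)c2cc1OC` gives 110 nM in this assay.

For the measured compounds named here, compound 2 stands at the higher of the two numbers measured so far; the only measured step, a 1.6-fold higher number from compound 1 to compound 2 (0.20 log units; within the scatter), lies within the scatter. Compound 3 `COc1cc2nc(N3CCC(N(C)CCCO)CC3)nc(Nc3ccc(Cl)cc3)c2cc1OC` differs from compound 2 by (3-hydroxypropyl)(methyl)amino in place of pyrrolidin-1-yl on a saturated ring carbon. Going by the values given here, no measured step touches this saturated ring carbon; the one known step concerns only the aryl group and so offers no direct guide. An amino group remains on that ring carbon, and compound 3 is expected to give about 150 nM, between 50 nM and 500 nM, which is an expected step of a 1.4-fold higher number from compound 2 to compound 3 (0.13 log units; within the scatter).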

Compound 3, half-maximal inhibitory concentration: 280 nM
Estimate against measurement, compound 3: 1.9-fold (0.27 log units) below, within the range that was stated.
By their numbers in this assay, from the lowest: compounds 1 and 2 (each within the scatter of the next); then compound 3.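

In this assay, this saturated ring carbon proves sensitive to its substituent: (3-hydroxypropyl)(methyl)amino in place of pyrrolidin-1-yl gives a 2.5-fold higher number from compound 2 to compound 3 (0.41 log units; beyond the scatter), a modest step but beyond the scatter, unlike the earlier aryl change. An amino group stays on this carbon, yet the open chain does not keep the number of the pyrrolidin-1-yl compound. No measurement available here accounts for the step. The ring and the hydroxyl change together in this step, and the compounds shown do not separate them. Going by these compounds, how a piperidin-1-yl group or a (3-methoxypropyl)(methyl)amino group would read at this carbon remains open.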